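Working notes on a small fluoro-to-trifluoromethyl series

A few compounds are considered here, and "the series" means these few. Any claim that something is new, unique, unknown or untested is made for them only; others in the source may bear on it.

Measured so far in a functional assay on the whole organism (strain Swiss) with Mus musculus as the target, in the maximal electroshock model, with a stated time of 2 h, at a dose of 100 mg/kg by the intraperitoneal route; a higher number here means a stronger effect of the compound at the dose given, a lower number a weaker effect:
compound 1, `CCC(C(=O)N1CCN(c2cccc(F)c2)CC1)N1C(=O)CCC1=O`, gives 0%;
compound 2, `CC(C(=O)N1CCN(c2ccccc2F)CC1)N1C(=O)CCC1=O`, gives 0%;
compound 3, `CC(C(=O)N1CCN(c2ccccc2C(F)(F)F)CC1)N1C(=O)CCC1=O`, gives 0%.

All three measured compounds sit level with one another in this assay at the digits reported, within the usual scatter. How compound 1 and compound 2 differ in their cores is not broken down here. Between compound 2 and compound 3 the change is trifluoromethyl in place of fluoro on an aromatic carbon, and the step it made is no change at the digits printed from compound 2 to compound 3 (within the scatter).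

Compound 4, `CCC(C(=O)N1CCN(c2cccc(C(F)(F)F)c2)CC1)N1C(=O)CCC1=O`, is not yet measured. It differs from compound 1 by trifluoromethyl in place of fluoro on an aromatic carbon. For the measured compounds named here, this is the same kind of change as the one from compound 2 to compound 3, but not the same: around the place, the change in compound 3 is ortho to a large group, while in compound 4 it is meta to a large group.

The expectation for compound 4 rests on the measured step: because no change at the digits printed from compound 2 to compound 3 (within the scatter) showed nothing beyond the scatter, and because compound 1 gives 0%, the step from compound 1 to compound 4 is expected to be no change at the digits printed from compound 1 to compound 4 (within the scatter). On that basis compound 4 is estimated to give 0% in this assay, with an expected range from 0% to 15%. Only the two compounds carrying this change are available, so no wider pattern is claimed.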

Compound 4, a percentage reported as activity, at one dose (the size of the read-out at that dose, not a potency): 0%
For compound 4 middle estimate and measured number coincide at the digits printed; measured number inside the range.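

Within this assay, trifluoromethyl in place of fluoro on an aromatic carbon now has a second reading, no change at the digits printed from compound 1 to compound 4 (within the scatter), and the two cores agree: the same change on two cores in this assay, no change at the digits printed (within the scatter) from compound 2 to compound 3 and no change at the digits printed (within the scatter) from compound 1 to compound 4, 0 percentage points apart, within the scatter of two such steps.

What this shows is narrow: on these two cores, the exchange leaves the read-out as it was at this single dose, even though the place differs, with the group in compound 4 meta to a large group. It does not show that the change is neutral in general, since compound 1 and compound 4 both stand with no effect recorded, compound 4 at 0%, and steps that begin and end with no effect say nothing about how the same change would behave on a core that gives a measurable effect in this assay.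

The compounds shown leave open whether any other group on the aromatic ring, such as an amine or a carboxylic acid in place of fluoro or trifluoromethyl, would give a reading different from these. They also leave open whether a longer chain on the shared core would alter the read-out, and whether the exchange would then still carry from one core to another.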